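The source may hold more compounds than are shown below. What is called first, only, known or untested is meant among the compounds shown, and "the series" means these compounds.

Measured compounds:
Compound 1 `c1ccc(-c2cn(C(c3ccccc3)c3ccccc3)nn2)cc1` — 12900 nM
Compound 2 `O=[N+]([O-])c1ccc(OCc2cn(C(c3ccccc3)c3ccccc3)nn2)cc1` — 11600 nM

Of the compounds shown here, two have been measured in an assay on isolated protein for inhibition of Aromatase (Homo sapiens), read by fluorescence and colorimetric assay, with a stated time of 30 min; a lower number here means a stronger inhibitor, a higher number a weaker inhibitor. Compound 1 gives 12900 nM and compound 2 gives 11600 nM, which is the lower of the two numbers; the gap between them lies within the scatter of this assay, so neither can be called the stronger inhibitor. Compound 3 `Cc1ccc(OCc2cn(C(c3ccccc3)c3ccccc3)nn2)cc1` has not yet been measured. It differs from compound 2 in one place: methyl in place of nitro on an aromatic carbon, para to a large group. Going by the values given here, no comparable step between measured compounds is available, so there is nothing in the data that points to a shift in either direction. The step from compound 2 to compound 3 is therefore expected to stay within the scatter, a 1.1-fold higher number from compound 2 to compound 3 (0.05 log units; within the scatter). Compound 3 is estimated at 13000 nM, with a range from 5000 nM to 35000 nM.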

Compound 3, half-maximal inhibitory concentration: 26800 nM
Compound 3: middle estimate off by 2.1-fold (0.31 log units), on the low side, within the range that was stated.
By their numbers in this assay, from the lowest: compounds 2 and 1 (each within the scatter of the next); then compound 3.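

In this assay, going by these compounds alone, the change from 4-nitrophenyl to 4-methylphenyl gives the first step beyond the scatter in this set (a 2.3-fold higher number from compound 2 to compound 3 (0.36 log units; beyond the scatter)), so the group on this aromatic carbon, para to a large group, does bear on the number, and here methyl gives the weaker inhibitor. Swapping phenyl on an aromatic carbon for (4-methylphenoxy)methyl also gives a step beyond the scatter (a 2.1-fold higher number from compound 1 to compound 3 (0.32 log units; beyond the scatter)), whereas compound 1 and compound 2 could not be told apart. The data shown offer no measurement that explains these steps.

With only nitro and methyl at this place, the compounds shown leave open how a plain hydrogen, a chlorine or an amine would read there. They also leave open whether a longer chain in place of methyl would give a stronger or a weaker inhibitor.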